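The source may report more compounds than this note shows. Statements on the series, on what has been measured and on what is new or still open speak of the compounds shown alone.

Compound 1 `C=C(CC)C(=O)c1ccc(OCC(=O)Nc2nc3ccccc3s2)c(Cl)c1Cl`: 1500 nM
Compound 2 `C=C(CC)C(=O)c1ccc(OCC(=O)Nc2cccc(C(=O)O)c2)c(Cl)c1Cl`: 20600 nM
Compound 3 `C=C(CC)C(=O)c1ccc(OCC(=O)Nc2ccc(O)c(Cl)c2)c(Cl)c1Cl`: 5500 nM

In a functional assay on CLL cells (Homo sapiens) for cytotoxicity, read by MTT assay, with a stated time of 48 h (a higher number here means that more compound is needed for the effect, a lower number that less compound is needed), these three compounds share one core and differ only in the group on the amide-type nitrogen. Compound 3 stands second highest of the three numbers: the step of a 3.7-fold higher number from compound 1 to compound 3 (0.56 log units; beyond the scatter) separates it from compound 1, and the step of a 3.7-fold lower number from compound 2 to compound 3 (0.57 log units; beyond the scatter) from compound 2. Compound 4 `C=C(CC)C(=O)c1ccc(OCC(=O)NC(CS)C(=O)OCC)c(Cl)c1Cl` is not yet measured; it differs from compound 3 by 1-(ethoxycarbonyl)-2-sulfanylethyl in place of 3-chloro-4-hydroxyphenyl on an amide-type nitrogen. Among the compounds with values here, no measured step swaps an aromatic group for a chain, so the bearing steps, the large 14-fold higher number from compound 1 to compound 2 (1.14 log units; beyond the scatter) and the modest 3.7-fold lower number from compound 2 to compound 3 (0.57 log units; beyond the scatter), only show that this position shifts the number appreciably. A modest rise is therefore expected, a 2.2-fold higher number from compound 3 to compound 4 (0.34 log units; beyond the scatter). Compound 4 is estimated to give 12000 nM, within 4000 nM to 40000 nM.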

Compound 4, half-maximal effective concentration: 4800 nM
The estimate for compound 4 lay 2.5-fold (0.40 log units) above the measured number; measured number inside the range.
By their numbers in this assay, from the lowest: compound 1; then compounds 4 and 3 (each within the scatter of the next); then compound 2.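

In this assay, an open chain can take the place of an aromatic ring on the amide-type nitrogen: 1-(ethoxycarbonyl)-2-sulfanylethyl in place of 3-chloro-4-hydroxyphenyl gives (a 1.1-fold lower number from compound 3 to compound 4 (0.06 log units; within the scatter)). The chain does not close the gaps to the other two aromatic groups, with (a 4.3-fold lower number from compound 2 to compound 4 (0.63 log units; beyond the scatter)) and (a 3.2-fold higher number from compound 1 to compound 4 (0.51 log units; beyond the scatter)), so compound 1 keeps the lowest number of the four. Nothing measured here explains these results.

On these data alone, it remains open whether the sulfanyl or the ethoxycarbonyl part of the chain matters, and whether a chain carrying an amine or a carboxylic acid instead, or a longer chain, would give a similar number.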